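Triazole nitrogen substituent: cyclopropyl for dimethylaminoethyl

The source may hold more compounds than are shown below. What is called first, only, known or untested is meant among the compounds shown, and "the series" means these compounds.

Compound 1 `CN(C)CCn1cnnc1-c1cc(Oc2ccc(NC(=O)Nc3ccc(Cl)c(C(F)(F)F)c3)cc2F)ccn1` is the reference for this step. In a functional assay on HT-29 cells (Homo sapiens) for antiproliferative activity, read by MTT assay, with a stated time of 72 h (a lower number here means a stronger inhibitor, a higher number a weaker inhibitor), compound 1 gives 880 nM. Compound 2 `CN(C)CCn1cnnc1-c1cc(Oc2ccc(NC(=O)Nc3ccc(F)c(Cl)c3)cc2F)ccn1` gives 720 nM and compound 3 `CN(C)CCn1cnnc1-c1cc(Oc2ccc(NC(=O)Nc3ccc(Cl)cc3Cl)cc2F)ccn1` gives 1890 nM. Among these three numbers compound 1 stands second highest; the step of a 1.2-fold lower number from compound 1 to compound 2 (0.09 log units; within the scatter) lies within the scatter, whereas a 2.1-fold higher number from compound 1 to compound 3 (0.33 log units; beyond the scatter) is beyond it and modest, as is a 2.6-fold higher number from compound 2 to compound 3 (0.42 log units; beyond the scatter).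

Compound 4 `O=C(Nc1ccc(Oc2ccnc(-c3nncn3C3CC3)c2)c(F)c1)Nc1ccc(Cl)c(C(F)(F)F)c1` differs from compound 1 by cyclopropyl in place of 2-(dimethylamino)ethyl on an aromatic nitrogen. Every measured step in the series alters only the aryl group on an amide-type nitrogen; none alters the group on the aromatic nitrogen of the triazole. Within the data shown here, no measured step therefore bears directly on this change. Among the measured compounds shown here, what the measured steps do show is that the whole series so far spans only a modest range, with no step larger than the one from compound 2 to compound 3.

With nothing measured at the changed position, the working expectation for compound 4 is a number close to that of compound 1, with a wide allowance in either direction. Compound 4 is estimated at 1000 nM, with a range from 300 nM to 3500 nM. The expected step of a 1.1-fold higher number from compound 1 to compound 4 (0.06 log units; within the scatter) is within the scatter.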

Compound 4, half-maximal inhibitory concentration: 10900 nM
Compound 4: the middle estimate sits 11-fold (1.04 log units) below what was measured; the measured number lies above the stated range.
By their numbers in this assay, from the lowest: compounds 2 and 1 (each within the scatter of the next); then compound 3; then compound 4.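

In this assay, the change at the aromatic nitrogen gives a 12-fold higher number from compound 1 to compound 4 (1.09 log units; beyond the scatter), a step larger than any seen among the aryl changes on the amide-type nitrogen, of which the largest is a 2.6-fold higher number from compound 2 to compound 3 (0.42 log units; beyond the scatter). Among these compounds, this position therefore carries much more weight than the earlier compounds could show, and with the 4-chloro-3-(trifluoromethyl)phenyl group held constant, 2-(dimethylamino)ethyl is clearly preferred here over cyclopropyl. The change alters several things at once, replacing an open chain of 5 heavy atoms that includes a nitrogen with an all-carbon three-membered ring, and no available data explain the loss of activity.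

The compounds shown cannot separate the contribution of the amine nitrogen from that of the chain, a question that an all-carbon 3-methylbutyl group or a longer 3-(dimethylamino)propyl chain at the same nitrogen would address. Also open, as far as these compounds go, is whether cyclopropyl brings a step of similar size alongside 3-chloro-4-fluorophenyl or 2,4-dichlorophenyl on the amide-type nitrogen.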